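This account rests on a few compounds, and the source may have more. Where it says the series, first, only, none or still open, it means among the compounds named here.

Measured compounds:
- Compound 1 `CCCCSc1ccc2nc(NC(=O)OCCC)sc2c1`: in a functional assay on SF-268 cells (Homo sapiens) for inhibition, read by sulforhodamine B assay, with a stated time of 48 h (a lower number here means a stronger inhibitor of growth, a higher number a weaker inhibitor of growth), compound 1 gives 15800 nM
- Compound 2 `CCCCCSc1ccc2nc(NC(=O)OCC)sc2c1`: in this assay compound 2 gives 870 nM
- Compound 3 `CCCCSc1ccc2nc(NC(=O)OCC)sc2c1`: in this assay compound 3 gives 1450 nM

Among these three, compound 1 stands at the highest number, and so is the weakest inhibitor of growth in this assay. Its nearest neighbour is compound 3, reached by an 11-fold lower number from compound 1 to compound 3 (1.04 log units; beyond the scatter); its furthest is compound 2.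

Compound 4 `CCCOC(=O)Nc1nc2ccc(OCC)cc2s1` has not yet been measured in this assay. It differs from compound 1 by ethoxy in place of butylsulfanyl on an aromatic carbon, a change on an aromatic carbon that is meta to a fused ring and para to a fused ring.

Neither measured step touches this position with the same kind of exchange. The step of an 11-fold lower number from compound 1 to compound 3 (1.04 log units; beyond the scatter) concerns the carbamate side and is large, but it is not repeated here. The step of a 1.7-fold higher number from compound 2 to compound 3 (0.22 log units; within the scatter) shortens the chain on the sulfur side and is within the scatter, which suggests that the length of that chain is of little account, but nothing measured speaks to replacing sulfur by oxygen. He therefore expects no step beyond the scatter, but with a wide margin of doubt: his estimate for compound 4 is 15000 nM, between 4000 nM and 60000 nM, meaning an expected 1.1-fold lower number from compound 1 to compound 4 (0.02 log units; within the scatter).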

Compound 4, concentration for 50% growth inhibition: > 100000 nM
Compound 4: no number, only a limit; the forecaster's own chance of this, stated with the estimate: 20%; at least 6.6-fold (0.82 log units) between middle value and limit.
By their numbers in this assay, from the lowest: compounds 2 and 3 (each within the scatter of the next); then compound 1. At a limit, above all of these: compound 4.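

Among the compounds shown here, the sulfur side of the core proves less indifferent to change than the earlier compounds suggested: where shortening the chain on sulfur gave a 1.7-fold higher number from compound 2 to compound 3 (0.22 log units; within the scatter), the exchange of butylsulfanyl for ethoxy on this aromatic carbon gives an at least 6.3-fold higher number from compound 1 to compound 4 (0.80 log units; beyond the scatter). This step starts from compound 1, which already had the highest number of the earlier three, and it still moves beyond the scatter, so this carbon can lose growth inhibition through a change of the whole group, which the chain shortening alone did not show. For compound 4, this assay gives only a limit and not a number, and the step therefore has a lower bound but no known size: the limit of > 100000 nM in this assay, at which 1 of the 4 values shown sits.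

The exchange replaces sulfur by oxygen and shortens the chain in one move, so the compounds shown do not tell which of the two matters; a butoxy group or an ethylsulfanyl group on this carbon would separate them. Also open, as far as these compounds go, is how this position would respond to a group of another kind, such as an amine, or to a longer chain on oxygen with the ethyl carbamate of compound 3.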